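From a 3-fluorophenyl to a 2,4,5-trimethylphenyl group

The source may hold more compounds than are shown below. What is called first, only, known or untested is meant among the compounds shown, and "the series" means these compounds.

Three compounds sharing one core have numbers in a functional assay on KBVIN cells (Homo sapiens) for antiproliferative activity, read by sulforhodamine B assay, with a stated time of 3 days; a lower number here means that less compound is needed, a higher number that more compound is needed for the effect. Compound 1 `CCC1=C(O)c2c(oc(-c3ccc(C(C)C)cc3)cc2=O)C(CC)(CC)C1=O` gives 1.08 uM, compound 2 `CCC1=C(O)c2c(oc(-c3ccc(COC)cc3)cc2=O)C(CC)(CC)C1=O` gives 3.4 uM, and compound 3 `CCC1=C(O)c2c(oc(-c3cccc(F)c3)cc2=O)C(CC)(CC)C1=O` gives 3.09 uM. Compound 3 cannot be told apart from one neighbour, with a 1.1-fold lower number from compound 2 to compound 3 (0.04 log units; within the scatter). The other neighbour is clearly separated, with a 2.9-fold higher number from compound 1 to compound 3 (0.46 log units; beyond the scatter).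

Compound 4 `CCC1=C(O)c2c(oc(-c3cc(C)c(C)cc3C)cc2=O)C(CC)(CC)C1=O` carries 2,4,5-trimethylphenyl in place of 3-fluorophenyl on an aromatic carbon, next to the ring oxygen: 2,4,5-trimethylphenyl in place of 3-fluorophenyl on an aromatic carbon. Going by the values given here, no measured compound carries this group, so the measured steps give only indirect guidance. The closest case is compound 1, whose aryl group likewise holds only carbon, at 1.08 uM. Replacing isopropyl with methoxymethyl on that aryl group gives a modest step, a 3.1-fold higher number from compound 1 to compound 2 (0.50 log units; beyond the scatter). On that thin basis, a move towards compound 1 is expected in this assay, toward a lower number but only part of the way, and perhaps not beyond the scatter. The estimated step is a 1.7-fold lower number from compound 3 to compound 4 (0.23 log units; within the scatter). For compound 4 the expected value is 1.8 uM, with an estimated range from 0.8 uM to 4 uM.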

Compound 4, concentration for half-maximal effect: 4.37 uM
For compound 4 the middle estimate is 2.4-fold (0.39 log units) below the measured one; measured number above the stated range.
By their numbers in this assay, from the lowest: compound 1; then compounds 3, 2 and 4 (each within the scatter of the next).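

In this assay, 2,4,5-trimethylphenyl in place of 3-fluorophenyl gives a 1.4-fold higher number from compound 3 to compound 4 (0.15 log units; within the scatter) and, against the 4-(methoxymethyl)phenyl group, a 1.3-fold higher number from compound 2 to compound 4 (0.11 log units; within the scatter) so at this aromatic carbon next to the ring oxygen, three quite different aryl groups cannot be told apart. The new result also shows that an aryl group holding only carbon does not by itself bring the low number of compound 1: the change from 4-isopropylphenyl to 2,4,5-trimethylphenyl gives a 4.0-fold higher number from compound 1 to compound 4 (0.61 log units; beyond the scatter) and leaves compound 1 alone, beyond the scatter from each of the other three. No evidence is at hand to say what sets the 4-isopropylphenyl group apart from 2,4,5-trimethylphenyl in this position.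

The compounds shown leave open whether the lower number of compound 1 belongs to the isopropyl group itself or would also appear with a tert-butyl group or a longer alkyl chain on the aryl ring. They also leave open how this assay would respond to an amine or a carboxylic acid on that ring, since all the aryl groups here carry neither.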